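This account rests on a few compounds, and the source may have more. Where it says the series, first, only, none or still open, it means among the compounds named here.

Compound 1 `CC1CCN(C2CCN(S(=O)(=O)c3cccc(C(F)(F)F)c3)CC2)CC1` carries a trifluoromethyl on the aromatic ring attached to the sulfonyl group. In a functional assay on DLD-1 cells (Homo sapiens) for antiproliferative activity, read by CellTiter-Glo, with a stated time of 72 h (on this read-out lower numbers stand for stronger inhibition and higher numbers for weaker inhibition), compound 1 gives > 5000 nM, which is a limit of the assay rather than a number. Compound 1 therefore sits at the limit of > 5000 nM in this assay, at which 1 of the 2 values shown sits. Compound 2 `Cc1cc(C)c(S(=O)(=O)NCCN2CCC(C)CC2)c(C)c1` is a looser relative built on a different linker, and in this assay compound 2 gives 1900 nM. Among the compounds with values here, no step between compound 1 and compound 2 has been worked out, so the two values show only that one is a number and the other a limit.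

Compound 3 `COc1ccc(-c2cccc(S(=O)(=O)N3CCC(N4CCC(C)CC4)CC3)c2)cc1` has not yet been measured. It differs from compound 1 in one place: 4-methoxyphenyl in place of trifluoromethyl on an aromatic carbon. Within the data shown here, no measured pair covers this kind of change, so the expectation rests on little. The step is expected to come out at an at least 1.6-fold lower number from compound 1 to compound 3 (0.22 log units; that floor lies within the scatter), a modest gain in potency that may not clear the usual scatter. On that basis compound 3 is expected to give 3000 nM in this assay, within a range from 800 nM to 10000 nM.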

Compound 3, half-maximal inhibitory concentration: 23 nM
Compound 3: middle estimate off by 130-fold (2.12 log units), on the high side; the whole stated range lies above it.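

Replacing trifluoromethyl with 4-methoxyphenyl on this aromatic carbon gives, in this assay, an at least 210-fold lower number from compound 1 to compound 3 (2.33 log units; beyond the scatter), so a change at this single place on the shared core can move the read-out far beyond the usual scatter. The change swaps a group with no ring for a larger one that brings a six-membered aromatic ring of carbon only and a hydrogen-bond acceptor, and this one step cannot say which of these differences matters. The value of compound 1 is a limit of the assay and not a number, so the step gives only a floor and its full size remains unknown: the limit of > 5000 nM in this assay, at which 1 of the 3 values shown sits.

The compounds shown leave open whether the gain belongs to the added phenyl ring or to its methoxy group, a question on which a plain phenyl or a 4-hydroxyphenyl at the same carbon would bear. They also leave open how the new ring would respond to other groups in place of the methoxy, such as an amine or a carboxylic acid.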